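Replacing 4-methoxyphenyl in compound 3 with 3,5-dimethylphenyl

A few compounds are considered here, and "the series" means these few. Any claim that something is new, unique, unknown or untested is made for them only; others in the source may bear on it.

Measured so far in a functional assay on BaF3 cells (Mus musculus) for inhibition, read by MTT assay, with a stated time of 3 days; a lower number here means a stronger inhibitor of growth, a higher number a weaker inhibitor of growth
- Compound 1 `O=C(Nc1ccc(Nc2ncnc3c2OCCN3)cc1)Nc1ccc(Cl)c(C(F)(F)F)c1` gives > 10000 nM (a limit)
- Compound 2 `O=C(Nc1ccc(Nc2ncnc3c2OCCN3)cc1)Nc1ccc(C(F)(F)F)cc1` gives 10000 nM
- Compound 3 `COc1ccc(NC(=O)Nc2ccc(Nc3ncnc4c3OCCN4)cc2)cc1` gives > 10000 nM (a limit)

Compound 3 gives > 10000 nM as a limit of the assay and not a number. The series is marked by the limit of > 10000 nM in this assay, at which 2 of the 3 values shown sit, as its main feature. The change to compound 4 `Cc1cc(C)cc(NC(=O)Nc2ccc(Nc3ncnc4c3OCCN4)cc2)c1` is 3,5-dimethylphenyl in place of 4-methoxyphenyl on an amide-type nitrogen. Among the measured compounds shown here, the one measured step that bears on it is a number no lower from compound 2 to compound 3 (the limit leaves the size open) and its size cannot be read. For the measured compounds named here, compound 2 gives 10000 nM as the only real number, so compound 4 is expected to stay weak in this assay as well. The expected step is a number no higher from compound 3 to compound 4 (the limit leaves the size open) with no clear gain. Compound 4 is estimated at 10000 nM with an expected range from 4000 nM to 20000 nM.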

Compound 4, concentration for 50% growth inhibition: > 10000 nM
Compound 4 was reported as a limit (the forecaster's own chance of this, stated with the estimate: 75%); the middle value sits exactly at the limit.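

In this assay compound 4 gives > 10000 nM, which is a limit of the assay and not a number. The data show a number no lower from compound 2 to compound 4 (the limit leaves the size open). The sizes of that step and of the step to compound 4 from compound 3 cannot be read. Placing the all-carbon 3,5-dimethylphenyl on the amide-type nitrogen, where compound 3 carries 4-methoxyphenyl, thus puts compound 4 with compound 1 and compound 3, with compound 2 the one exception, in the feature that marks the series: the limit of > 10000 nM in this assay, at which 3 of the 4 values shown sit.

How far any of these compounds lies past the limit stays open. So does the effect of an amine or a carboxylic acid on this aromatic ring, or of a longer chain in its place.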